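The source may hold more compounds than are shown below. What is called first, only, known or untested is meant among the compounds shown, and "the series" means these compounds.

Measured so far:
compound 1, `CC(C)C[C@H](NCc1ccc(C(=N)N)cc1)C(=O)[C@@H](CCCNC(=N)N)NS(=O)(=O)Cc1ccccc1`, in an assay on isolated protein for inhibition of transmembrane protease serine 11D (Homo sapiens), read by fluorescence (on this read-out lower numbers stand for stronger inhibition and higher numbers for weaker inhibition), compound 1 gives 47 nM
compound 2, `N=C(N)NCCC[C@@H](NS(=O)(=O)Cc1ccccc1)C(=O)[C@H](CC(=O)O)NCc1ccc(C(=N)N)cc1`, in this assay compound 2 gives 422 nM

Among the compounds with values here, compound 2 stands highest of the two numbers in this assay; its nearest neighbour is compound 1, and the single step between them, a 9.0-fold higher number from compound 1 to compound 2 (0.95 log units; beyond the scatter), is beyond the scatter. Compound 3, `CC(C)(C)OC(=O)C[C@H](NCc1ccc(C(=N)N)cc1)C(=O)[C@@H](CCCNC(=N)N)NS(=O)(=O)Cc1ccccc1`, differs from compound 2 by tert-butyl in place of hydrogen on an oxygen next to a carbonyl group. Within the data shown here, no measured pair here shows hydrogen against tert-butyl on such an oxygen, so the only step that bears on this region is the one from compound 1 to compound 2, where the carboxy group in place of isopropyl raised the number. Compound 3 keeps the carbon framework of that position but caps the oxygen, so the step is expected to lie somewhere between no change and a partial return toward compound 1, without a direct precedent to fix its size. For compound 3 the step of a 2.8-fold lower number from compound 2 to compound 3 (0.45 log units; beyond the scatter) is therefore expected to be a downward one of uncertain size. Compound 3 is estimated at 150 nM in this assay, within 40 nM to 600 nM.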

Compound 3, inhibition constant: 512 nM
Compound 3: the middle estimate sits 3.4-fold (0.53 log units) below what was measured; measured number inside the range.
By their numbers in this assay, from the lowest: compound 1; then compounds 2 and 3 (each within the scatter of the next).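

In this assay, tert-butyl in place of hydrogen on this oxygen gives a 1.2-fold higher number from compound 2 to compound 3 (0.08 log units; within the scatter), so the free carboxy group of compound 2 and the tert-butoxycarbonyl group of compound 3 cannot be told apart on this read-out, even though the change adds 4 heavy atoms. Set against the isopropyl compound, the capped group gives an 11-fold higher number from compound 1 to compound 3 (1.04 log units; beyond the scatter), so the higher number seen on leaving compound 1 does not depend on the hydrogen of the carboxy group: it appears with that hydrogen in compound 2 and with tert-butyl in its place in compound 3. No measurement offered here explains why the two groups read alike or why both stand apart from isopropyl.

The three compounds do not settle whether the shift from compound 1 goes with the carbonyl group shared by compounds 2 and 3 or with the loss of isopropyl itself. A primary amide or a methyl ester on this chain carbon could help separate these readings, as could a longer hydrocarbon chain with no carbonyl, such as n-butyl.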